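Aryltriazene carboxamides: chain lengthening at the amine nitrogen

The source may report more compounds than this note shows. Statements on the series, on what has been measured and on what is new or still open speak of the compounds shown alone.

Among the compounds with values here, two aryltriazene carboxamides have numbers so far. Compound 1 `CCCCN(C)/N=N/c1ccc([N+](=O)[O-])cc1C(N)=O` carries a nitro group on the core and a butyl with a methyl on the triazene nitrogen; in a functional assay on L1210 cells (Mus musculus) for antiproliferative activity (on this read-out higher numbers stand for higher potency (the scale is a negative logarithm) and lower numbers for lower potency), compound 1 gives 3.08. Compound 2 `CN(C)/N=N/c1ccccc1C(N)=O` has two methyls on that nitrogen and no nitro group; in this assay compound 2 gives 3.31. Compound 2 holds the higher of the two numbers, but the gap to compound 1 falls within the usual scatter, so the two cannot be ordered on these data.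

Compound 3 `CCCCN(C)/N=N/c1ccccc1C(N)=O` has not been measured. It differs from compound 2 by propyl in place of hydrogen on a saturated chain carbon bound to an amine nitrogen; taken one bond further out, the same difference reads methyl to butyl. Compound 1, which already carries the butyl, sits close to compound 2, which offers no sign that the longer chain moves the read-out much. In this assay the step of a number 0.11 log units lower from compound 2 to compound 3 (within the scatter) is therefore expected to stay within the scatter. The estimate for compound 3 is 3.2, with a range from 2.7 to 3.7.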

Compound 3, logarithm of the reciprocal of the active concentration, log(1/C): 3.1
For compound 3 the middle estimate is 0.10 log units above the measured one; the measured number falls inside the stated range.
By their numbers in this assay, from the lowest: compounds 1, 3 and 2 (each within the scatter of the next).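

In this assay, propyl in place of hydrogen on a saturated chain carbon bound to an amine nitrogen gives a number 0.21 log units lower from compound 2 to compound 3 (within the scatter) and thus reads methyl to butyl directly on a core without the nitro group, and this change does not separate the two compounds. With the butyl held fixed, hydrogen in place of nitro on an aromatic carbon gives a number 0.02 log units higher from compound 1 to compound 3 (within the scatter) and does not separate that pair either, so the two changes combined in the earlier comparison can now be read one at a time, each within the scatter. Nothing given here bears on why these numbers lie so close together.

Chains longer than butyl, a branched chain or a ring on the amine nitrogen, and a chain ending in a hydroxyl or an amine lie outside the compounds shown, so the limits of this position remain open. At the aromatic carbon only nitro and hydrogen appear, which leaves groups such as methoxy or chlorine open, along with a carboxylic acid or a nitrile in place of the carboxamide.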